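Swapping the acetyl pyrazole for a methylsulfonyl pyrazole

The compounds below may be only part of what the source reports. "The series", "measured", "known", "first", "only" and "open" are said of these compounds alone.

For the measured compounds named here, in a functional assay on MV4-11 cells (Homo sapiens) for antiproliferative activity, with a stated time of 6 days, tested at 6.25 uM (on this read-out lower numbers stand for a weaker effect and higher numbers for a stronger effect at the one concentration tested), compound 2 `CNC(=O)N1CCCc2ccc(NC(=O)c3ccc(-c4ccn(C(C)=O)n4)cc3)cc21` gives 91.4%, the highest of the three numbers measured so far. Compound 3 `CNC(=O)N1CCCc2ccc(NC(=O)c3cccc(-c4cnn(C(C)=O)c4)c3)cc21` gives 82%, which lies within the scatter of compound 2. Compound 1 `CNC(=O)N1CCCc2ccc(NC(=O)c3ccc(-c4ccccc4)cc3)cc21` gives 74.3%, and the step of a number 17.1 percentage points higher from compound 1 to compound 2 (beyond the scatter) is a modest gain. Compound 4 `CNC(=O)N1CCCc2ccc(NC(=O)c3ccc(-c4cnn(S(C)(=O)=O)c4)cc3)cc21` has not been measured yet; it differs from compound 2 by 1-(methylsulfonyl)-1H-pyrazol-4-yl in place of 1-acetyl-1H-pyrazol-3-yl on an aromatic carbon. Going by the values given here, only that one measured step bears on this change, and it exchanged a whole ring, whereas here the pyrazole stays and only the group on its nitrogen changes. Compounds 2 and 3 show that two acetyl pyrazoles give numbers within the scatter of each other. A step of a number 5.4 percentage points lower from compound 2 to compound 4 (within the scatter) is therefore expected. Compound 4 is estimated at 86%, between 66% and 97%.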

Compound 4, a percentage reported as inhibition, at one concentration (the size of the read-out at that concentration, not a potency): 40.2%
The estimate for compound 4 lay 45.8 percentage points above the measured number; measured number outside the range, below it.
By their numbers in this assay, from the lowest: compound 4; then compounds 1, 3 and 2 (each within the scatter of the next, the first and the last beyond it).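

In this assay, replacing the group on the aromatic carbon para to a large group gives a number 51.2 percentage points lower from compound 2 to compound 4 (beyond the scatter), and replacing the plain phenyl gives a number 34.1 percentage points lower from compound 1 to compound 4 (beyond the scatter). A pyrazole at this place is therefore no guarantee of a high number, since compound 2 and compound 4 both carry one. Nothing measured here explains the loss. Both the group on the ring nitrogen and the ring's point of attachment change in this step, so 1-acetyl-1H-pyrazol-4-yl at this place would be needed to separate them. On these data alone, how a pyrazole bearing a simple methyl or an amine would behave also stays open.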